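Working notes: methyl for cyclopropyl on an amide-type nitrogen

This account rests on a few compounds, and the source may have more. Where it says the series, first, only, none or still open, it means among the compounds named here.

Measured so far in a functional assay on HCT-116 cells (Homo sapiens) for antiproliferative activity, read by sulforhodamine B assay, with a stated time of 72 h; on this read-out lower numbers stand for stronger inhibition and higher numbers for weaker inhibition:

- compound 1 `Cn1ncc(Cl)c1-c1cc(C(=O)N[C@H]2CNCC[C@@H]2c2ccc(C(F)(F)F)cc2)oc1Cl` gives 1050 nM
- compound 2 `Cn1ncc(Cl)c1-c1cc(C(=O)N[C@@H]2CN[C@H](CC(=O)NC3CC3)C[C@H]2c2ccc(Cl)c(Cl)c2)oc1Cl` gives 740 nM
- compound 3 `Cn1ncc(Cl)c1-c1cc(C(=O)N[C@@H]2CN[C@H](CC(O)CO)C[C@H]2c2ccc(F)c(F)c2)oc1Cl` gives 800 nM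

Compound 2 shows the lowest of the three numbers, yet compound 3 and compound 1 both sit within the usual scatter of it, so no order among the three can be claimed in this assay.

Compound 4 `CNC(=O)C[C@@H]1C[C@@H](c2ccc(Cl)c(Cl)c2)[C@H](NC(=O)c2cc(-c3c(Cl)cnn3C)c(Cl)o2)CN1` is the next candidate. Relative to compound 2 it carries a single change: methyl in place of cyclopropyl on an amide-type nitrogen. Among the measured compounds shown here, no measured pair in this set documents such a change, so there is no step to lean on. A group this small, at a position this far from the shared core, is expected to shift the number little, if at all, with no clear direction.

The estimate for compound 4 in this assay is therefore a step of a 1.1-fold higher number from compound 2 to compound 4 (0.06 log units; within the scatter), giving an expected value of 850 nM with a range from 400 nM to 1800 nM.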

Compound 4, half-maximal inhibitory concentration: 450 nM
Beside the measured number, compound 4's estimate is 1.9-fold (0.28 log units) above it; the range from low to high includes it.
By their numbers in this assay, from the lowest: compounds 4, 2, 3 and 1 (each within the scatter of the next, the first and the last beyond it).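

In this assay, among the compounds shown here, methyl in place of cyclopropyl on an amide-type nitrogen gives a 1.6-fold lower number from compound 2 to compound 4 (0.22 log units; within the scatter), the first matched comparison at this position. The three-membered ring is therefore not required to keep the number in the range of compound 2, and the change leaves the read-out within the scatter. Nothing available explains this step.

The compounds shown leave open how a longer chain, such as ethyl or a hydroxyethyl group, would read on this nitrogen. On these data alone, whether an amine or a carboxylic acid at the end of such a chain would be tolerated also remains open.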